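Ethyl on the amide nitrogen of compound 3

The source may report more compounds than this note shows. Statements on the series, on what has been measured and on what is new or still open speak of the compounds shown alone.

Three compounds share one core. In an assay on isolated protein for inhibition of Myeloperoxidase (Homo sapiens), read by ELISA, with a stated time of 5 min (a higher number here means a weaker inhibitor, a lower number a stronger inhibitor), compound 1 `N#CSCCCc1c[nH]c2ccc(F)cc12` gives 23 nM, compound 2 `NC(=O)CCc1c[nH]c2ccc(F)cc12` gives 34 nM and compound 3 `NC(=O)CCCc1c[nH]c2ccc(F)cc12` gives 18 nM; compound 3 sits at the low end of a spread in which no two values lie apart beyond the scatter. The chain changes, a 1.5-fold higher number from compound 1 to compound 2 (0.17 log units; within the scatter), a 1.3-fold lower number from compound 1 to compound 3 (0.11 log units; within the scatter) and a 1.9-fold lower number from compound 2 to compound 3 (0.28 log units; within the scatter), all stay within the scatter. Compound 4 `CCNC(=O)CCCc1c[nH]c2ccc(F)cc12` carries ethyl in place of hydrogen on an amide-type nitrogen. Among the measured compounds shown here, no measured step touches the amide nitrogen, so only the flat picture across the series informs the expectation. For compound 4 in this assay the estimate is 22 nM, ranging from 9 nM to 55 nM, an expected step of a 1.2-fold higher number from compound 3 to compound 4 (0.09 log units; within the scatter), none beyond the scatter.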

Compound 4, half-maximal inhibitory concentration: 243 nM
Compound 4: the middle estimate sits 11-fold (1.04 log units) below what was measured, outside the stated range (above it).
By their numbers in this assay, from the lowest: compounds 3, 1 and 2 (each within the scatter of the next); then compound 4.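

In this assay, among the compounds shown here, the amide nitrogen is the first place where a single change goes beyond the scatter: ethyl in place of hydrogen gives a 14-fold higher number from compound 3 to compound 4 (1.13 log units; beyond the scatter). Compound 4 also stands apart from the other two chains, with a 7.1-fold higher number from compound 2 to compound 4 (0.85 log units; beyond the scatter) and an 11-fold higher number from compound 1 to compound 4 (1.02 log units; beyond the scatter). No supporting data bear on what lies behind this result. Open, from the compounds shown here alone, is whether methyl or cyclopropyl on the amide nitrogen would read closer to compound 3 or to compound 4, and whether a longer chain there would go further in the same direction.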